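Dropping one methoxy group: what to expect

This account rests on a few compounds, and the source may have more. Where it says the series, first, only, none or still open, it means among the compounds named here.

Compound 2 `COc1cc(C2Oc3c(OC)cc(/C=C/C=O)cc3C2CO)cc(OC)c1O` was tested in a functional assay on HepG2 cells (Homo sapiens) for cytotoxicity, read by MTT assay, with a stated time of 48 h (a higher number here means a weaker inhibitor, a lower number a stronger inhibitor), where compound 2 gives 80500 nM. Among the compounds with values here, that is the lowest of the two numbers known so far, but only narrowly: compound 1 `COc1cc([C@@H]2Oc3c(OC)cc(/C=C/C=O)cc3[C@H]2CO)cc(OC)c1O` gives 104000 nM in this assay, and the step of a 1.3-fold lower number from compound 1 to compound 2 (0.11 log units; within the scatter) stays within the scatter. The two compounds have the same atoms and bonds; the fact that one of compounds 1 and 2 is drawn with a defined configuration and the other without, at the place where they differ is all that separates them, so their two numbers read as a single result.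

Compound 3 `COc1cc(C2Oc3c(OC)cc(/C=C/C=O)cc3C2CO)ccc1O` has not yet been measured in this assay. It differs from compound 2 in one place: hydrogen in place of methoxy on an aromatic carbon. Within the data shown here, no measured step bears on this change: the one recorded step, a 1.3-fold lower number from compound 1 to compound 2 (0.11 log units; within the scatter), concerns only how the stereocentres are drawn, not a change of substituent. With nothing pointing either way, no movement beyond the scatter is expected in this assay, so the step of a 1.0-fold lower number from compound 2 to compound 3 (0.00 log units; within the scatter) is expected to be small. Compound 3 is therefore estimated at 80000 nM, with a likely range from 30000 nM to 220000 nM.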

Compound 3, half-maximal inhibitory concentration: 36500 nM
For compound 3 the middle estimate is 2.2-fold (0.34 log units) above the measured one, and the stated range covers the measured number.
By their numbers in this assay, from the lowest: compound 3; then compounds 2 and 1 (each within the scatter of the next).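

Within the data shown here, this is the first change of substituent, and in this assay it gives a 2.2-fold lower number from compound 2 to compound 3 (0.34 log units; beyond the scatter), a modest step. It shows that the methoxy group ortho to a hydroxy group is not needed to keep this level of cytotoxicity: with hydrogen on that aromatic carbon the number falls rather than rises, while the hydroxy group and the other methoxy group on the ring stay in place. None of the measurements shown bears on why the number moves at this position.

As far as these compounds go, what stays open is whether the gain comes from losing the methoxy group or from having hydrogen there, which a fluorine atom, an ethoxy group or an amine on the same aromatic carbon would help to separate. Also open, from the compounds shown here alone, is what happens when the remaining methoxy group is changed too, and whether the same step appears when the stereocentres are defined, as they are in compound 1.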